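The compounds below may be only part of what the source reports. "The series", "measured", "known", "first", "only" and "open" are said of these compounds alone.

Measured in a functional assay on A549 cells (Homo sapiens) for antiproliferative activity, read by MTT assay; on this read-out lower numbers stand for stronger inhibition and higher numbers for weaker inhibition:
- Compound 1 `O=C1NC(c2ccccc2)CN1S(=O)(=O)c1ccc2c(c1)CCCN2`: > 20000 nM
- Compound 2 `O=C(c1ccccc1)N1CCCc2cc(S(=O)(=O)N3CC(c4ccccc4)NC3=O)ccc21`: 8140 nM

The value of compound 1 is a limit of the assay, not a number. For the measured compounds named here, compound 2 gives 8140 nM, the only exact number so far in this assay. Compound 3 `O=C(CCl)NC(=O)N1CCCc2cc(S(=O)(=O)N3CC(c4ccccc4)NC3=O)ccc21` has not yet been measured. It differs from compound 2 at one place: ((chloromethyl)carbonyl)amino in place of phenyl on a carbonyl carbon, with ((chloromethyl)carbonyl)amino in place of phenyl on a carbonyl carbon. Going by the values given here, one measured step bears on this, the addition of benzoyl: an at least 2.4-fold lower number from compound 1 to compound 2 (0.39 log units; beyond the scatter). On these data alone, its true size remains open, given (the limit of > 20000 nM in this assay, at which 1 of the 2 values shown sits). Among the compounds with values here, that step shows that a change on this nitrogen can register in the assay, but no measured step replaces the phenyl, so only a modest further drop is expected, and with wide uncertainty. The expected change is a 2.7-fold lower number from compound 2 to compound 3 (0.43 log units; beyond the scatter). For compound 3 the estimated value is 3000 nM, with an expected range of 500 nM to 15000 nM.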

Compound 3, half-maximal inhibitory concentration: 449 nM
Compound 3: middle estimate off by 6.7-fold (0.82 log units), on the high side, and the stated range ends above it.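

Putting ((chloromethyl)carbonyl)amino in place of phenyl on the carbonyl carbon gives an 18-fold lower number from compound 2 to compound 3 (1.26 log units; beyond the scatter) in this assay, which shows that the group on this carbonyl carbon can change the read-out far more than the addition of benzoyl alone revealed. Measured against hydrogen on the same nitrogen, the full ((chloromethyl)carbonyl)carbamoyl group gives an at least 44-fold lower number from compound 1 to compound 3 (1.64 log units; beyond the scatter). The true size of that step stays open, because the value of compound 1 is a limit of the assay, not a number: the limit of > 20000 nM in this assay, at which 1 of the 3 values shown sits.

The compounds shown leave open which part of the entering group matters, as the phenyl ring left and several new features came in together. A methyl in place of the chloromethyl, or a plain amino group on the carbonyl carbon, would help separate the role of the chlorine from that of the rest of the chain.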